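The compounds below may be only part of what the source reports. "The series", "measured", "known", "first", "only" and "open" are said of these compounds alone.

Measured so far:
compound 1, `CN(CCCn1ccnc1)C(=O)[C@@H]1CCCN1c1nccc(Nc2ccccc2)n1`: 1%
compound 2, `Cc1cccc(Nc2ncnc3c2CN(C(=O)c2ccc(N(C)C)c4ccccc24)CC3)c1`: 1%

In an assay on isolated protein for inhibition of Rho-associated protein kinase 2 (Homo sapiens), read by HTRF, tested at 10 uM (a higher number here means more inhibition at the concentration tested (going by the name of the read-out), a lower number less inhibition), compound 1 gives 1%, and compound 2 gives 1%; the two stand level, with no difference beyond the usual scatter, so compound 1 shows essentially no inhibition here. Compound 3, `CN(C)CC(C)(C)CNC(=O)[C@@H]1CCCN1c1nccc(Nc2ccccc2)n1`, differs from compound 1 in one place: (2-((dimethylamino)methyl)-2-methylpropyl)amino in place of (3-(1H-imidazol-1-yl)propyl)(methyl)amino on a carbonyl carbon. Among the compounds with values here, no measured pair shows what such a change does in this assay, so no step beyond the scatter is expected in either direction. Compound 3 is therefore expected to give 3%, between -8% and 15%, an expected step of a number 2 percentage points higher from compound 1 to compound 3 (within the scatter) that stays within the scatter.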

Compound 3, a percentage reported as inhibition, at one concentration (the size of the read-out at that concentration, not a potency): 0%
For compound 3 the middle estimate is 3 percentage points above the measured one; measured number inside the range.
By their numbers in this assay, from the lowest: compounds 3, 1 and 2 (each within the scatter of the next).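

In this first measured swap at the carbonyl carbon, replacing (3-(1H-imidazol-1-yl)propyl)(methyl)amino with (2-((dimethylamino)methyl)-2-methylpropyl)amino gives a number 1 percentage points lower from compound 1 to compound 3 (within the scatter) in this assay. Thus, losing the five-membered aromatic ring and gaining a hydrogen-bond donor does not lift compound 3 beyond the scatter from compound 1. No measurement here offers an explanation for this result. As far as these compounds go, whether a carboxylic acid or a longer chain ending in a primary amine on this carbonyl carbon would give more inhibition stays open. So does whether any compound with this shared core can give clear inhibition.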